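The source may hold more compounds than are shown below. What is called first, only, known or untested is meant among the compounds shown, and "the series" means these compounds.

Compound 2 `COc1ccc(-c2cc3ccccc3nc2/C=C/C(=O)c2ccc[nH]2)cc1` reaches only the limit of > 10000 nM in a functional assay on MDA-MB-231 cells (Homo sapiens) for antiproliferative activity, read by XTT assay, with a stated time of 72 h (on this read-out higher numbers stand for weaker inhibition and lower numbers for stronger inhibition), so no number stands for it. Its relative compound 1 `COc1ccc(-c2cc3ccccc3nc2/C=C/C(=O)c2ccc(O)cc2)cc1` gives 6350 nM in this assay. Within the data shown here, the single measured step, an at least 1.5-fold higher number from compound 1 to compound 2 (0.19 log units; that floor lies within the scatter), exchanged the group on the carbonyl carbon, and it ends at the limit of > 10000 nM in this assay, at which 1 of the 2 values shown sits. Compound 3 `COc1ccc(-c2cc3ccccc3nc2/C=C/C(=O)c2sccc2N)cc1` differs from compound 2 by 3-aminothiophen-2-yl in place of 1H-pyrrol-2-yl on a carbonyl carbon. Among the measured compounds shown here, no measured step covers this exchange, and the one step known leads into the weak region. For compound 3 the expected step in this assay is a number no higher from compound 2 to compound 3 (the limit leaves the size open), giving an estimate of 10000 nM, between 3000 nM and 30000 nM.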

Compound 3, half-maximal inhibitory concentration: > 10000 nM
Compound 3 ended at the assay's limit; the forecaster's own chance of this, stated with the estimate: 55%; the middle value lies on the limit itself.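

In this assay, a second replacement of 4-hydroxyphenyl on the carbonyl carbon, this time by 3-aminothiophen-2-yl, again yields a limit rather than a number, with an at least 1.5-fold higher number from compound 1 to compound 3 (0.19 log units; that floor lies within the scatter). The step between the 1H-pyrrol-2-yl and 3-aminothiophen-2-yl groups cannot be read, so these two groups cannot be ranked. Among the groups shown at this place, only 4-hydroxyphenyl gives a number, and the limit now holds most of the series: the limit of > 10000 nM in this assay, at which 2 of the 3 values shown sit.

From the compounds shown here alone, how far compound 2 and compound 3 lie past that limit remains open. Also open, going by these compounds, is what a 4-aminophenyl group on this carbonyl carbon would give in this assay.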